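Methyl Added to the Anilino Ring of a Urea

A few compounds are considered here, and "the series" means these few. Any claim that something is new, unique, unknown or untested is made for them only; others in the source may bear on it.

Measured compounds:
Compound 1 `O=C(Nc1ccccc1)Nn1c(-c2ccccc2)nc2ccccc2c1=O` gives 56% in a functional assay on the whole organism (strain albino) with Mus musculus as the target, at a dose of 100 mg/kg by the intraperitoneal route; a higher number here means more inhibition at the dose given (going by the name of the read-out), a lower number less inhibition.
Compound 2 `CCc1nc2ccccc2c(=O)n1NC(=O)Nc1ccccc1` gives 54% in this assay.
Compound 3 `Cc1cccc(NC(=O)Nn2c(-c3ccccc3)nc3ccccc3c2=O)c1` gives 59% in this assay.

Compound 2 has the smallest number of the three, but the gaps to compound 1 and to compound 3 both lie within the usual scatter, so the three compounds cannot be told apart on these numbers. The two measured steps are small: a number 2 percentage points lower from compound 1 to compound 2 (within the scatter), and a number 3 percentage points higher from compound 1 to compound 3 (within the scatter).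

The unmeasured compound 4 `CCc1nc2ccccc2c(=O)n1NC(=O)Nc1ccc(C)cc1` arises from compound 2 by the change (methyl in place of hydrogen on an aromatic carbon). The step from compound 1 to compound 3 is the same kind of change on a different aromatic carbon, and it gave a number 3 percentage points higher from compound 1 to compound 3 (within the scatter), a shift inside the scatter. Going by the values given here, no other measured step bears on this change. The expectation is therefore that the step from compound 2 to compound 4 stays within the scatter in this assay, with no clear direction.

Compound 4 is estimated to give 56% in this assay, within a range of 44% to 68%, which corresponds to an expected step of a number 2 percentage points higher from compound 2 to compound 4 (within the scatter).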

Compound 4, a percentage reported as inhibition, in the whole organism at one dose (the size of the read-out at that dose, not a potency): 55%
Beside the measured number, compound 4's estimate is 1 percentage points above it; measured number inside the range.
By their numbers in this assay, from the lowest: compounds 2, 4, 1 and 3 (each within the scatter of the next).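

In this assay, putting 4-methylphenyl in place of phenyl on the urea of the ethyl-bearing core gives a number 1 percentage points higher from compound 2 to compound 4 (within the scatter), so the methyl, placed para to a large group on the anilino ring, brings no change that can be told from the scatter. Until now this change had been seen only once, on a different aromatic carbon and on the core that carries phenyl, so a single small step could have been peculiar to that one compound pair. With a second pair in hand, the same change on two different cores, at two different ring carbons, gives steps that cannot be told apart, and neither pair shows a clear shift: the same change on two cores in this assay, a number 3 percentage points higher (within the scatter) from compound 1 to compound 3 and a number 1 percentage points higher (within the scatter) from compound 2 to compound 4, 2 percentage points apart, within the scatter of two such steps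

Going by these compounds, what remains open is whether a group other than methyl at this para carbon, such as a chlorine atom, a methoxy group or a carboxylic acid, would give a step beyond the scatter. On these data alone, it is also open whether a longer chain such as butyl in place of the ethyl would do so, and these single-dose percentages say nothing about potency.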